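The source may report more compounds than this note shows. Statements on the series, on what has been measured and on what is new or still open speak of the compounds shown alone.

Measured compounds:
Compound 1, `Cc1ccc(C2C(C#N)=C(N)N(c3ccc(S(N)(=O)=O)cc3)C3=C2C(=O)CCC3)cc1`, gives 50% in a functional assay on Ehrlich cells (Mus musculus) for antiproliferative activity, read by trypan blue exclusion, with a stated time of 2 h, tested at 50 ug/mL; a lower number here means a weaker effect, a higher number a stronger effect of the compound at the concentration tested.
Compound 2, `COc1ccccc1C1C(C#N)=C(N)N(c2ccc(S(N)(=O)=O)cc2)C2=C1C(=O)CCC2`, gives 0% in this assay.

Compound 1 stands highest of the two numbers in this assay; its nearest neighbour is compound 2, reached by the step of a number 50 percentage points lower from compound 1 to compound 2 (beyond the scatter), which lies beyond the scatter. Compound 3, `COc1cc(CC2C(C#N)=C(N)N(c3ccc(S(N)(=O)=O)cc3)C3=C2C(=O)CCC3)ccc1O`, has not yet been measured in this assay. It differs from compound 1 in one place: 4-hydroxy-3-methoxybenzyl in place of 4-methylphenyl on a saturated ring carbon. Going by the values given here, only one measured step bears on this change, a number 50 percentage points lower from compound 1 to compound 2 (beyond the scatter), and it also exchanges the 4-methylphenyl group on the same saturated ring carbon; that step was large and downward. Among the compounds with values here, no measured step covers the 4-hydroxy-3-methoxybenzyl group itself, so the expectation rests on that single exchange alone. Within the data shown here, a downward step in this assay beyond the scatter is therefore expected for compound 3, with a wide margin because a number 50 percentage points lower from compound 1 to compound 2 (beyond the scatter) is the only guide. Compound 3 is expected to give 15%, within a range from 0% to 45%. That estimate means an expected step of a number 35 percentage points lower from compound 1 to compound 3 (beyond the scatter).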

Compound 3, a percentage reported as activity, at one concentration (the size of the read-out at that concentration, not a potency): 90%
For compound 3 the middle estimate is 75 percentage points below the measured one; the whole stated range lies below it.
By their numbers in this assay, from the lowest: compound 2; then compound 1; then compound 3.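

Going by these compounds alone, until now the only exchange on this saturated ring carbon had lowered the read-out, but in this assay the 4-hydroxy-3-methoxybenzyl group gives a number 40 percentage points higher from compound 1 to compound 3 (beyond the scatter) and so shows that a change at this position can also raise it. Set against the 2-methoxyphenyl group, the same entering group gives a number 90 percentage points higher from compound 2 to compound 3 (beyond the scatter) on an otherwise unchanged core, so the group on this one carbon is enough to separate a compound with no measurable effect from the highest number among the three compounds at the concentration tested. Nothing at hand explains why this group lifts the number.

The 4-hydroxy-3-methoxybenzyl group differs from 4-methylphenyl in more than one feature at once, so these compounds do not show whether the rise goes with the benzyl form, the hydroxyl or the methoxy group; an unsubstituted benzyl, a 4-hydroxybenzyl and a 3-methoxybenzyl group would pull these apart. Each compound also stands at a single concentration, which leaves open how the three would rank in potency across a range of concentrations.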